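Thiophene variation on the camphor-type amine core: cytotoxicity notes

The compounds below may be only part of what the source reports. "The series", "measured", "known", "first", "only" and "open" are said of these compounds alone.

Measured so far:
compound 1 `C[C@H]1[C@H](NCc2cc(Br)cs2)C[C@H]2C[C@@H]1C2(C)C`, 6250 nM
compound 2 `C[C@H]1[C@H](NCc2ccc(Cl)s2)C[C@H]2C[C@@H]1C2(C)C`, 25000 nM

Compound 2 holds the highest number of the two in an ADME assay on MDCK cells (Canis lupus familiaris) for cytotoxicity, read by microscopy, with a stated time of 48 h; on this read-out higher numbers stand for lower toxicity in this test and lower numbers for higher toxicity in this test; compound 1 is the nearest, a 4.0-fold higher number from compound 1 to compound 2 (0.60 log units; beyond the scatter) away. Compound 3 `C[C@H]1[C@H](NCc2sccc2Br)C[C@H]2C[C@@H]1C2(C)C` is not yet measured; it differs from compound 2 by 3-bromothiophen-2-yl in place of 5-chlorothiophen-2-yl on a saturated chain carbon bound to an amine nitrogen. Among the measured compounds shown here, the only measured step, from compound 1 to compound 2, changes both the halogen and its position, so it bears on this change only loosely; it shows that a bromo-bearing thiophene gave the lower number. A step back toward the lower number is therefore expected for compound 3, a 2.0-fold lower number from compound 2 to compound 3 (0.30 log units; within the scatter), with wide uncertainty. Compound 3 is estimated at 12500 nM, range 3000 nM to 50000 nM.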

Compound 3, minimum cytotoxic concentration: 50000 nM
Compound 3: the middle estimate sits 4.0-fold (0.60 log units) below what was measured; low and high end bracket the measured number.
By their numbers in this assay, from the lowest: compound 1; then compounds 2 and 3 (each within the scatter of the next).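

With the bromine kept, an 8.0-fold higher number from compound 1 to compound 3 (0.90 log units; beyond the scatter) in this assay, so the place of the halogen on the thiophene alone separates these two compounds, which the earlier step, changing halogen and place together, could not show. By contrast, a 2.0-fold higher number from compound 2 to compound 3 (0.30 log units; within the scatter), so 3-bromothiophen-2-yl and 5-chlorothiophen-2-yl are not told apart here. No measurement at hand accounts for either step.

Still open, from the compounds shown here alone, is whether a phenyl ring in place of the thiophene, or a methyl group in place of the halogen, would stay with compound 2 and compound 3 or with compound 1.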